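The source may hold more compounds than are shown below. What is called first, only, known or untested is meant among the compounds shown, and "the series" means these compounds.

Measured compounds:
compound 1 `CCC1(Cc2ccccc2)OS(=O)(=O)C=C1OCc1ccc(OC)cc1` — > 200000 nM
compound 2 `CCC1(Cc2ccccc2)OS(=O)(=O)C=C1OCc1ccc(Br)cc1` — 171000 nM
compound 3 `CCC1(Cc2ccccc2)OS(=O)(=O)C=C1OCc1ccccc1` — 200000 nM

In an ADME assay on HEL cells (Homo sapiens) for cytotoxicity, with a stated time of 3 days (a lower number here means that less compound is tolerated, a higher number that more compound is tolerated), compound 3 gives 200000 nM, the higher of the two numbers reported. Its nearest neighbour is compound 2, and the change a 1.2-fold higher number from compound 2 to compound 3 (0.07 log units; within the scatter) does not rise above the scatter. For compound 1 the assay reports only a limit, > 200000 nM, not a number, the limit of > 200000 nM in this assay, at which 1 of the 3 values shown sits, marking the top of the measured range.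

Compound 4 `CCC1(Cc2ccccc2)OS(=O)(=O)C=C1OCc1ccc(C(C)(C)C)cc1` differs from compound 3 in one place: tert-butyl in place of hydrogen on an aromatic carbon. The three measured compounds all vary at this same aromatic carbon, so the steps of an at least 1.1-fold lower number from compound 1 to compound 2 (0.06 log units; that floor lies within the scatter), a number no higher from compound 1 to compound 3 (the limit leaves the size open) and a 1.2-fold higher number from compound 2 to compound 3 (0.07 log units; within the scatter) bear on it directly. None of them reaches beyond the scatter, and one of them is capped by the limit. The tert-butyl group has not been tried, but the methoxy, bromo and hydrogen variants give no sign that this position moves the read-out in this assay.

For compound 4 the expected step of a 1.1-fold lower number from compound 3 to compound 4 (0.05 log units; within the scatter) is therefore one that stays within the scatter. Compound 4 is estimated at 180000 nM, with a range from 90000 nM to 300000 nM, and with a fair chance that this assay again reports only a limit.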

Compound 4, half-maximal cytotoxic concentration: 200000 nM
Compound 4: middle estimate off by 1.1-fold (0.05 log units), on the low side; the measured number falls inside the stated range.
By their numbers in this assay, from the lowest: compounds 2, 3 and 4 (each within the scatter of the next).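

Placing a tert-butyl group, with its 4 heavy atoms, on this aromatic carbon leaves the read-out in this assay without a change that can be told from noise: the result is no change at the digits printed from compound 3 to compound 4 (within the scatter), and the comparison with the bromo variant gives a 1.2-fold higher number from compound 2 to compound 4 (0.07 log units; within the scatter). The earlier compounds shown here had covered only hydrogen, bromo and methoxy here, so compound 4 extends the flat picture among compounds 2, 3 and 4 to a carbon-only group with no ring and with 0 hydrogen-bond donors and 0 hydrogen-bond acceptors. The remaining comparison gives a number no higher from compound 1 to compound 4 (the limit leaves the size open), because the earlier value in it is only a limit and not a number: the limit of > 200000 nM in this assay, at which 1 of the 4 values shown sits.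

The compounds shown leave open whether an amine or a carboxylic acid on this same aromatic carbon would move the read-out in this assay. They also leave open whether a longer chain elsewhere on the shared core would do so, as all four compounds keep that core unchanged.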